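This account rests on a few compounds, and the source may have more. Where it says the series, first, only, none or still open, it means among the compounds named here.

In a functional assay on the whole organism for inhibition, with Rattus norvegicus as the target, read by cytopathic effect and paw edema, at a dose of 100 mg/kg by the oral route (on this read-out higher numbers stand for more inhibition at the one dose given (going by the name of the read-out) and lower numbers for less inhibition), compound 1 `CNC(=O)c1c(O)c2cccnc2n(-c2ccccc2)c1=O` gives 21%.
Compound 2 `O=C(NCc1ccccc1)c1c(O)c2cccnc2n(-c2ccccc2)c1=O` gives 11.3%.
Compound 3 `COc1ccc(NC(=O)c2c(O)c3cccnc3n(-c3ccccc3)c2=O)cc1` gives -1.9%.

Compound 3 stands lowest of the three: the nearest number is that of compound 2, reached through a number 13.2 percentage points lower from compound 2 to compound 3 (beyond the scatter), and the furthest that of compound 1, reached through a number 22.9 percentage points lower from compound 1 to compound 3 (beyond the scatter). Compound 4 `Cc1ccccc1NC(=O)c1c(O)c2cccnc2n(-c2ccccc2)c1=O` differs from compound 3 in one place: 2-methylphenyl in place of 4-methoxyphenyl on an amide-type nitrogen. Both steps into compound 3 put 4-methoxyphenyl on the amide-type nitrogen in place of a smaller group and lowered inhibition modestly; no measured step swaps one aromatic ring for another on that nitrogen, so the direction of this change is not shown. The expected step is therefore a number 4.9 percentage points higher from compound 3 to compound 4 (within the scatter), within the scatter. Compound 4 is estimated at 3%, between -12% and 18%.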

Compound 4, a percentage reported as inhibition, in the whole organism at one dose (the size of the read-out at that dose, not a potency): 9.8%
Beside the measured number, compound 4's estimate is 6.8 percentage points below it; low and high end bracket the measured number.
By their numbers in this assay, from the lowest: compound 3; then compounds 4, 2 and 1 (each within the scatter of the next, the first and the last beyond it).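

Changing one aromatic ring for another on the amide-type nitrogen does alter the result (a number 11.7 percentage points higher from compound 3 to compound 4 (beyond the scatter)), so the low value of compound 3 is not shared by every aromatic group there. The 2-methylphenyl and benzyl groups cannot be told apart (a number 1.5 percentage points lower from compound 2 to compound 4 (within the scatter)). The small methyl group remains ahead of 2-methylphenyl (a number 11.2 percentage points lower from compound 1 to compound 4 (beyond the scatter)).

No measurement on hand explains these differences. Also open, going by these compounds, is how unsubstituted phenyl, 2-methoxyphenyl or a longer chain such as propyl would fare on that nitrogen.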